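The compounds below may be only part of what the source reports. "The series", "measured", "known", "first", "only" and "open" are said of these compounds alone.

In an ADME assay on KB cells (Homo sapiens) for cytotoxicity (a higher number here means that more compound is needed for the effect, a lower number that less compound is needed), compound 1 `CCOC(=O)N1[C@@H]2C=C[C@@](OC)(C(=O)c3c2cc(OC)c(OC)c3OCC)N1C(=O)OCC` gives > 300 ug/mL, which is a limit and not a number. Compound 2 `COC(=O)N1[C@@H]2C=C[C@@](OC)(C(=O)c3c2cc(OC)c(OC)c3OCc2ccc(OC)cc2)N1C(=O)OC` gives > 300 ug/mL, again a limit. Both compounds thus share (the limit of > 300 ug/mL in this assay, at which 2 of the 2 values shown sit). Compound 3 `CCOC(=O)N1[C@@H]2C=C[C@@](OC)(C(=O)c3c2cc(OC)c(OC)c3OCc2ccc(OC)cc2)N1C(=O)OCC` differs from compound 1 by one change, 4-methoxyphenyl in place of methyl on a saturated chain carbon bound to an oxygen on an aromatic ring. With compound 1 resting at the limit of > 300 ug/mL, no step beyond the scatter is expected in this assay. The estimated a number no higher from compound 1 to compound 3 (the limit leaves the size open) is small. For compound 3 the expected value is 300 ug/mL, with an estimated range of 120 ug/mL to 600 ug/mL.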

Compound 3, concentration for half-maximal effect: 63.1 ug/mL
Compound 3: the middle estimate sits 4.8-fold (0.68 log units) above what was measured; measured number below the stated range.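

At this position the change registers clearly: in this assay, 4-methoxyphenyl in place of methyl on a saturated chain carbon bound to an oxygen on an aromatic ring gives an at least 4.7-fold lower number from compound 1 to compound 3 (0.67 log units; beyond the scatter). Compound 3 is the only compound shown with a number rather than a limit, so the true size of the step stays unfixed: the limit of > 300 ug/mL in this assay, at which 2 of the 3 values shown sit.

On these data alone, how a plain phenyl or a propyl chain at this place would read in this assay remains open, and so does whether the methoxy on the ring matters to the step.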